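This account rests on a few compounds, and the source may have more. Where it says the series, first, only, none or still open, it means among the compounds named here.

Compound 1 `O=C1C(=Cc2ccc(O)cc2)C(=O)N(c2ccc(Cl)cc2)N1c1ccc(Cl)cc1`, compound 2 `CN(C)c1ccc(C=C2C(=O)N(c3ccc(Cl)cc3)N(c3ccc(Cl)cc3)C2=O)cc1` and compound 3 `COc1ccc(C=C2C(=O)N(c3ccc(Cl)cc3)N(c3ccc(Cl)cc3)C2=O)cc1` share one core and differ only in the group carried on the aromatic ring. In a functional assay on MGC-803 cells (Homo sapiens) for cytotoxicity, read by MTT assay, with a stated time of 72 h (a lower number here means a stronger inhibitor, a higher number a weaker inhibitor), compound 1 gives 19500 nM, while compound 2 gives 80200 nM, the highest of the two numbers measured. For compound 3 this assay reports only a limit, > 128000 nM. The step of a 4.1-fold higher number from compound 1 to compound 2 (0.61 log units; beyond the scatter) was modest, the step of an at least 6.5-fold higher number from compound 1 to compound 3 (0.81 log units; beyond the scatter) at least modest, and the step of an at least 1.5-fold higher number from compound 2 to compound 3 (0.20 log units; that floor lies within the scatter) lies within the scatter. Compound 4 `O=C1C(=Cc2ccco2)C(=O)N(c2ccc(Cl)cc2)N1c1ccc(Cl)cc1` differs from compound 2 by furan-2-yl in place of 4-(dimethylamino)phenyl on a double-bonded chain carbon bound to a double-bonded ring carbon. Among the measured compounds shown here, no measured step exchanges the whole aromatic ring, so none bears directly on this change, and the measured steps show only modest movements. Compound 4 is therefore expected to give a number close to that of compound 2. The estimate for compound 4 is 60000 nM, expected to fall between 20000 nM and 128000 nM, meaning a 1.3-fold lower number from compound 2 to compound 4 (0.13 log units; within the scatter).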

Compound 4, half-maximal inhibitory concentration: 12800 nM
The estimate for compound 4 lay 4.7-fold (0.67 log units) above the measured number; the measured number lies below the stated range.
By their numbers in this assay, from the lowest: compounds 4 and 1 (each within the scatter of the next); then compound 2. At a limit, above all of these: compound 3.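

Exchanging the whole aromatic ring on the double-bonded chain carbon gives a 6.3-fold lower number from compound 2 to compound 4 (0.80 log units; beyond the scatter), and also an at least 10-fold lower number from compound 3 to compound 4 (1.00 log units; beyond the scatter), so this position responds to the ring itself and not only to the group the ring carries. Furan-2-yl in place of 4-hydroxyphenyl gives a 1.5-fold lower number from compound 1 to compound 4 (0.18 log units; within the scatter), so the hydroxy group of compound 1 is not needed to reach this level. For compound 3 the assay gives only a limit: the limit of > 128000 nM in this assay, at which 1 of the 4 values shown sits.

As far as these compounds go, whether the oxygen of furan-2-yl matters stays open, and thiophen-2-yl or plain phenyl at this place would address it. Also open, from the compounds shown here alone, is how a furan ring carrying an amine or a carboxylic acid would behave.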